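Lengthening the Chain on an Aromatic Nitrogen

The source may report more compounds than this note shows. Statements on the series, on what has been measured and on what is new or still open speak of the compounds shown alone.

Compound 2 `C/C=C/n1cc(/C=C/C(=O)CC(=O)C(=O)OCC)c2ccccc21` is measured in an assay on isolated protein for inhibition of DNA nucleotidylexotransferase (Homo sapiens), read by scintillation counting, with a stated time of 10 min; on this read-out lower numbers stand for stronger inhibition and higher numbers for weaker inhibition. In this assay compound 2 gives > 40 uM, which is a limit of the assay rather than a number. Compound 1 `CCOC(=O)C(=O)CC(=O)/C=C/c1cn(CCC(C)C)c2ccccc12` likewise gives > 40 uM, also a limit. The step that the two limits leave unreadable from compound 1 to compound 2 is therefore unreadable, and both values sit at the limit of > 40 uM in this assay, at which 2 of the 2 values shown sit. Compound 3 `C/C=C/Cn1cc(/C=C/C(=O)CC(=O)C(=O)OCC)c2ccccc21` differs from compound 2 by but-2-en-1-yl in place of prop-1-en-1-yl on an aromatic nitrogen. Within the data shown here, no measured step bears on this change beyond those two limits, so no direction can be read from them. Compound 3 is estimated at 50 uM (range 20 uM to 150 uM), meaning an expected step that the limit leaves unreadable from compound 2 to compound 3 that is none beyond the scatter.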

Compound 3, concentration for 50% inhibition: > 40 uM
Compound 3: no number, only a limit; the forecaster's own chance of this, stated with the estimate: 80%; the middle value is on the limit's open side.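

Compound 1, compound 2 and compound 3 all sit at the same limit, so no step among them can be read: the limit of > 40 uM in this assay, at which 3 of the 3 values shown sit.

From the compounds shown here alone, how the chain on the aromatic nitrogen affects inhibition stays open.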